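Alkyne tail truncation in the phenylpropanoic acid series

The compounds below may be only part of what the source reports. "The series", "measured", "known", "first", "only" and "open" are said of these compounds alone.

Of the compounds shown here, two have been measured in a functional assay on 1321-N1 cells for agonist activity at Free fatty acid receptor 1 (Homo sapiens), read by calcium flux, with a stated time of 0.4 s; a lower number here means that less compound is needed, a higher number that more compound is needed for the effect. Compound 1 `O=C(O)CCc1ccc(C#CC2=CCCCC2)cc1` gives 200 nM in this assay, the lowest of the two numbers. Compound 2 `C/C(C#Cc1ccc(CCC(=O)O)c(F)c1)=C/CO` gives 427 nM in this assay; the gap between compound 1 and compound 2 lies beyond the usual scatter, but compound 2 differs from compound 1 in more than one place, so no single step can be read from that pair.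

Compound 3 `C=C(C)C#Cc1ccc(CCC(=O)O)cc1` is not yet measured. Against compound 1 the change is 1-methylethenyl in place of cyclohex-1-en-1-yl on a triple-bonded carbon: the six-membered ring is lost and a short open-chain group stands in its place. For the measured compounds named here, no step between measured compounds matches this change, so the direction rests on the structures alone and on the number for compound 1 alone. The expectation is that compound 3 needs more compound than compound 1, a moderate step beyond the scatter, estimated as a 4.0-fold higher number from compound 1 to compound 3 (0.60 log units; beyond the scatter). Compound 3 is therefore expected to give about 800 nM in this assay, within the range 250 nM to 2500 nM.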

Compound 3, half-maximal effective concentration: 417 nM
For compound 3 the middle estimate is 1.9-fold (0.28 log units) above the measured one; low and high end bracket the measured number.
By their numbers in this assay, from the lowest: compound 1; then compounds 3 and 2 (each within the scatter of the next).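

For the compounds shown here, replacing cyclohex-1-en-1-yl with 1-methylethenyl on the triple-bonded carbon gives the first single-place step, and in this assay it reads as a 2.1-fold higher number from compound 1 to compound 3 (0.32 log units; beyond the scatter), a modest change that lies beyond the scatter. The six-membered non-aromatic ring of carbon only is therefore not needed for a measurable response, since compound 3 , with an open-chain group of 3 heavy atoms in place of 6, still gives 417 nM in the same assay. Both groups carry 1 double bond outside aromatic rings, so the step comes with loss of the ring and of heavy atoms, but the data offer no explanation for it.

The two contributions remain inseparable here: the effect of losing the ring cannot be told from the effect of shortening the group. Also open, as far as these compounds go, is how a saturated cyclohexyl group, a phenyl ring or a longer open chain on the same triple-bonded carbon would read against compound 1 , and whether the double bond in these groups matters at all, which a saturated isopropyl group would test against compound 3 .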